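Series notes: fluoro on the phenyl of compound 3

The compounds below may be only part of what the source reports. "The series", "measured", "known", "first", "only" and "open" are said of these compounds alone.

Measured so far:
compound 1 `O=C1COc2ccc(-c3[nH]c(-c4c[nH]c5ncccc45)nc3-c3ccccc3)cc2N1` — 8.9%
compound 2 `O=C1COc2ccc(-c3nn(-c4ccc(F)cc4)cc3-c3ccccc3)cc2N1` — 92.6%
compound 3 `O=C1COc2ccc(-c3[nH]c(-c4ccccc4)nc3-c3ccccc3)cc2N1` — 7.6%

In a functional assay on MV4-11 cells (Homo sapiens) for cytotoxicity, read by colorimetric assay and MTT assay, with a stated time of 3 days, tested at 20 uM (a lower number here means a stronger effect, a higher number a weaker effect of the compound at the concentration tested), compound 3 stands lowest of the three numbers; compound 1 is nearest, within the scatter, and compound 2 is furthest, beyond it. Going by the values given here, the single measured step, a number 1.3 percentage points lower from compound 1 to compound 3 (within the scatter), concerns a different part of the molecule. Compound 4 `O=C1COc2ccc(-c3[nH]c(-c4ccc(F)cc4)nc3-c3ccccc3)cc2N1` differs from compound 3 by fluoro in place of hydrogen on an aromatic carbon. Among the compounds with values here, no measured step bears directly on this change; compound 2 carries the same 4-fluorophenyl on another core, and its value and that of compound 3 are far apart, which says nothing about the fluoro alone. A step of no size beyond the scatter is therefore expected, a number 2.4 percentage points higher from compound 3 to compound 4 (within the scatter). Compound 4 is estimated at 10%, with a range from 3% to 28%.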

Compound 4, a percentage reported as activity, at one concentration (the size of the read-out at that concentration, not a potency): 1.1%
Beside the measured number, compound 4's estimate is 8.9 percentage points above it, and the stated range ends above it.
By their numbers in this assay, from the lowest: compounds 4, 3 and 1 (each within the scatter of the next); then compound 2.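

On the phenyl of compound 3, the position para to a large group takes fluoro in this assay with a number 6.5 percentage points lower from compound 3 to compound 4 (within the scatter) on the shared core, so the low read-out holds with phenyl changed to 4-fluorophenyl. Set against the larger group of compound 1, the 4-fluorophenyl gives a number 7.8 percentage points lower from compound 1 to compound 4 (within the scatter) and so this place has taken all three groups without a step beyond the scatter. Nothing available explains this result. From the compounds shown here alone, whether an amine or a carboxylic acid at this position keeps the read-out stays open. A read-out at a single concentration also gives no potency for compound 1, compound 3 or compound 4.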